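This account rests on a few compounds, and the source may have more. Where it says the series, first, only, none or still open, it means among the compounds named here.

Measured compounds, percent of the compound remaining in an ADME assay on microsomes from liver (Mus musculus) for metabolic stability, read by LC-MS, with a stated time of 30 min, tested at 0.1 uM; a lower number here means that less of the compound is left, a higher number that more of the compound is left:

compound 1 `Fc1ccc(-c2nc3cnc(Nc4ccccn4)cc3[nH]2)cc1C(F)(F)F`: compound 1 gives 64%
compound 2 `Fc1ccc(-c2nc3cnc(Nc4ccccn4)cc3[nH]2)cc1F`: compound 2 gives 7.5%
compound 3 `Fc1ccc(-c2nc3cnc(Nc4ccc(C(F)(F)F)cn4)cc3[nH]2)cc1F`: compound 3 gives 89%

Compound 2 stands lowest of the three numbers in this assay; the nearest is compound 1, the furthest compound 3, both beyond the scatter. Compound 4 `Fc1ccnc(Nc2cc3[nH]c(-c4ccc(F)c(F)c4)nc3cn2)c1` has not yet been measured; it differs from compound 2 by fluoro in place of hydrogen on an aromatic carbon.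

Going by the values given here, two measured steps bear on this. The change a number 81.5 percentage points higher from compound 2 to compound 3 (beyond the scatter) puts a trifluoromethyl onto the same pyridine ring that carries the new fluoro in compound 4, and the change a number 56.5 percentage points lower from compound 1 to compound 2 (beyond the scatter) removes a trifluoromethyl for a fluoro on the other aryl ring. Neither is the same change as fluoro for hydrogen on the pyridine ring, and the shown compounds give no direct measure of a single fluoro there. On this basis a step in this assay upward from compound 2 is expected, smaller than the trifluoromethyl step, as a number 27.5 percentage points higher from compound 2 to compound 4 (beyond the scatter). Compound 4 is therefore estimated at 35%, in the range 10% to 70%.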

Compound 4, percent of the compound remaining: 18%
The estimate for compound 4 lay 17 percentage points above the measured number; the measured number falls inside the stated range.
By their numbers in this assay, from the lowest: compound 2; then compound 4; then compound 1; then compound 3.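

In this assay, going by these compounds alone, the change from pyridin-2-yl to 4-fluoropyridin-2-yl gives a number 10.5 percentage points higher from compound 2 to compound 4 (beyond the scatter), the first direct reading of a single fluoro on the carbon opposite the ring nitrogen. The step is modest though beyond the scatter, and compound 4 gives only 18%, so this one fluoro leaves the compound second lowest among the four shown. Nothing measured here speaks to what lies behind this step.

Still open, from the compounds shown here alone, is how other groups on this carbon would read, such as chloro, methoxy, nitrile, an amine or trifluoromethyl itself. Also open, going by these compounds, is whether the fluoro for hydrogen change gives a step of similar size when made on compound 1, which carries trifluoromethyl on the other aryl ring.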